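Nitro to amino at the same aromatic carbon

The source may hold more compounds than are shown below. What is called first, only, known or untested is meant among the compounds shown, and "the series" means these compounds.

Among the measured compounds shown here, in a functional assay on SGC-7901 cells (Homo sapiens) for antiproliferative activity, read by MTT assay, with a stated time of 72 h (on this read-out lower numbers stand for stronger inhibition and higher numbers for weaker inhibition), compound 2 `COc1ccc(-c2cc3[nH]nc(-c4cc(OC)c(OC)c(OC)c4)n3n2)cc1[N+](=O)[O-]` gives 48300 nM, the highest of the two numbers so far; its nearest neighbour is compound 1 `COc1ccc(-c2cc3[nH]nc(-c4cc(OC)c(OC)c(OC)c4)n3n2)cc1`, which in this assay gives 26800 nM. For the measured compounds named here, the single measured step, a 1.8-fold higher number from compound 1 to compound 2 (0.26 log units; within the scatter), lies within the scatter, so the two values cannot be ordered. Compound 3 `COc1ccc(-c2cc3[nH]nc(-c4cc(OC)c(OC)c(OC)c4)n3n2)cc1N` differs from compound 2 by amino in place of nitro on an aromatic carbon. Going by the values given here, only one measured step bears on this position, and it shows that changing the group at this carbon, from hydrogen to nitro, moved the number by a 1.8-fold higher number from compound 1 to compound 2 (0.26 log units; within the scatter), not beyond the scatter. On that basis the swap of nitro for amino is expected to give no step beyond the scatter either, with a slight lean toward a lower number. Compound 3 is therefore estimated at 35000 nM in this assay, with a range from 12000 nM to 100000 nM. The expected step is a 1.4-fold lower number from compound 2 to compound 3 (0.14 log units; within the scatter).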

Compound 3, half-maximal inhibitory concentration: 13800 nM
Beside the measured number, compound 3's estimate is 2.5-fold (0.40 log units) above it; the range from low to high includes it.
By their numbers in this assay, from the lowest: compounds 3, 1 and 2 (each within the scatter of the next, the first and the last beyond it).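

In this assay the exchange of nitro for amino gives a 3.5-fold lower number from compound 2 to compound 3 (0.54 log units; beyond the scatter) at this carbon, ortho to a methoxy group, so the group here can shift the number beyond the scatter, which the earlier hydrogen-to-nitro step did not show. Amino in place of hydrogen gives a 1.9-fold lower number from compound 1 to compound 3 (0.29 log units; within the scatter) and stays within the scatter, so only the two substituted compounds separate, while the unsubstituted compound cannot be ordered against either. No measurement accompanying these compounds bears on the reason for the step.

Open, as far as these compounds go, is whether a hydroxyl, an acetamide or a methylamino group at the same carbon would fall with amino or with nitro. Also open, from the compounds shown here alone, is whether the same exchange gives a similar step at another carbon of this ring.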